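The source may report more compounds than this note shows. Statements on the series, on what has been measured and on what is new or still open speak of the compounds shown alone.

Measured compounds in this series:
- compound 1: `COc1ccc(CCSc2nc(Cc3c(Cl)cccc3Cl)c(C)c(=O)[nH]2)cc1`
- compound 2: `Cc1c(O)nc(SCc2ccccc2)nc1Cc1c(Cl)cccc1Cl`
- compound 3: `COc1ccc(CS(=O)(=O)c2nc(O)c(C)c(Cc3c(Cl)cccc3Cl)n2)cc1`
- compound 4, not yet measured: `Cc1c(O)nc(SCc2ccc(Br)cc2)nc1Cc1c(Cl)cccc1Cl`

In a functional assay on MT4 cells (Homo sapiens) for cytotoxicity, read by MTT assay (on this read-out higher numbers stand for lower toxicity in this test and lower numbers for higher toxicity in this test), compound 1 reaches only a limit, > 57000 nM. Compound 2 likewise reaches only a limit in this assay, > 64000 nM. Compound 3 gives a number in this assay, 2800 nM. Compound 2 thus stands among the two compounds whose toxicity in this assay is known only as a limit, (the limit of > 64000 nM in this assay, at which 1 of the 3 values shown sits), alongside compound 1, (the limit of > 57000 nM in this assay, at which 1 of the 3 values shown sits); compound 3 alone lies at a value that could be read off.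

The step from compound 2 to compound 4 is a single change: bromo in place of hydrogen on an aromatic carbon. Among the measured compounds there is no pair differing in one place, so no measured step gives a yardstick for this change; the pairs among compounds 1, 2 and 3 show only that two remain at limits while one gives a number.

For compound 4 the expectation is that the step from compound 2 stays within the scatter, an at least 1.0-fold lower number from compound 2 to compound 4 (0.02 log units; that floor lies within the scatter), and that the assay most likely again reports a limit rather than a number. The estimated value for compound 4 is 60000 nM, with a range from 20000 nM to 200000 nM.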

Compound 4, half-maximal cytotoxic concentration: 13000 nM
Compound 4: the middle estimate sits 4.6-fold (0.66 log units) above what was measured; the whole stated range lies above it.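

In this assay, within the data shown here, bromo in place of hydrogen gives the first step between compounds that differ in one place: an at least 4.9-fold lower number from compound 2 to compound 4 (0.69 log units; beyond the scatter). This change from benzyl to 4-bromobenzyl therefore does not leave the read-out unchanged, and the lower number stands for higher toxicity in this test. Compound 2 gives only a limit, so the step sets a floor and not its full size, and nothing shown accounts for it.

From the compounds shown here alone, whether an amine, a carboxylic acid or a nitrile at this same place would move the number in the same direction remains open. Also open, going by these compounds, is whether bromo on another carbon of this aromatic ring would give a step of similar size.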